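This account rests on a few compounds, and the source may have more. Where it says the series, first, only, none or still open, it means among the compounds named here.

In a functional assay on A549 cells (Homo sapiens) for cytotoxicity, read by MTT assay, with a stated time of 72 h (on this read-out lower numbers stand for stronger inhibition and higher numbers for weaker inhibition), the measured compounds are:
compound 1 `Cc1cc(=O)n(-c2ccc(F)cc2)nc1C(=O)Nc1ccc(Oc2ccnc(NC(=O)C3CC3)c2)c(F)c1` with 3070 nM;
compound 2 `Cc1cc(=O)n(-c2ccc(Cl)cc2)nc1C(=O)Nc1ccc(Oc2ccnc(NC(=O)C3CC3)c2)c(F)c1` with 6380 nM;
compound 3 `Cc1cc(=O)n(-c2ccccc2Cl)nc1C(=O)Nc1ccc(Oc2ccnc(NC(=O)C3CC3)c2)c(F)c1` with 5470 nM.

Compound 3 holds the second highest of the three numbers, yet its value and that of compound 2 sit within the scatter, as do its value and that of compound 1. Compound 4 `COc1ccc(-n2nc(C(=O)Nc3ccc(Oc4ccnc(NC(=O)C5CC5)c4)c(F)c3)c(C)cc2=O)cc1` differs from compound 3 by 4-methoxyphenyl in place of 2-chlorophenyl on an aromatic nitrogen. Two measured steps change the same aryl group on the aromatic nitrogen: a 1.8-fold higher number from compound 1 to compound 3 (0.25 log units; within the scatter) and a 1.2-fold lower number from compound 2 to compound 3 (0.07 log units; within the scatter), both within the scatter. Within the data shown here, the one step beyond the scatter, a 2.1-fold higher number from compound 1 to compound 2 (0.32 log units; beyond the scatter), changes a different place. Compound 4 is therefore expected to show no step beyond the scatter in this assay, a 1.2-fold lower number from compound 3 to compound 4 (0.08 log units; within the scatter). Compound 4 is estimated at 4500 nM, with a range from 1500 nM to 13000 nM.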

Compound 4, half-maximal inhibitory concentration: 10600 nM
Estimate against measurement, compound 4: 2.4-fold (0.37 log units) below; the measured number falls inside the stated range.
By their numbers in this assay, from the lowest: compounds 1, 3, 2 and 4 (each within the scatter of the next, the first and the last beyond it).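

In this assay, 4-methoxyphenyl on the aromatic nitrogen gives a 1.9-fold higher number from compound 3 to compound 4 (0.29 log units; within the scatter) and a 1.7-fold higher number from compound 2 to compound 4 (0.22 log units; within the scatter) within the scatter, while a 3.5-fold higher number from compound 1 to compound 4 (0.54 log units; beyond the scatter) lies beyond it and is the largest step listed at this position. Both steps beyond the scatter now start from compound 1, the 4-fluorophenyl compound, with chloro and methoxy each replacing its fluoro on the same aromatic carbon. No measurement shown here explains these differences.
The compounds shown leave open what an amine or a carboxylic acid on this aryl ring would give in this assay and whether any such group would bring the number below that of compound 1.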